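The source may hold more compounds than are shown below. What is called first, only, known or untested is meant among the compounds shown, and "the series" means these compounds.

Measured compounds:
Compound 1, `COc1cccc(-c2cc(C(=O)Nc3ccc(Oc4ccnc5cc(OCCCN6CCCC6)c(OC)cc45)c(F)c3)c3ccccc3n2)c1`, gives 290 nM in a functional assay on NCI-H460 cells (Homo sapiens) for cytotoxicity, read by MTT assay, with a stated time of 72 h; on this read-out higher numbers stand for weaker inhibition and lower numbers for stronger inhibition.
Compound 2, `COc1cc2c(Oc3ccc(NC(=O)c4cc(-c5ccc(C)cc5)nc5ccccc45)cc3F)ccnc2cc1OCCCN1CCCC1`, gives 240 nM in this assay.
Compound 3, `COc1cccc(-c2cc(C(=O)Nc3ccc(Oc4ccnc5cc(OCCCN6CCC(C)CC6)c(OC)cc45)c(F)c3)c3cc(F)ccc3n2)c1`, gives 840 nM in this assay.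

Compound 1 and compound 2 share a core and differ in one place: 4-methylphenyl in place of 3-methoxyphenyl on an aromatic carbon. This change gave a 1.2-fold lower number from compound 1 to compound 2 (0.08 log units; within the scatter), so the two numbers are, for practical purposes, the same. Compound 3 carries the same group as compound 1 but on a different core; how the two cores differ is not broken down here. Compound 3 stands highest of the three measured numbers, and its gap to compound 1 lies beyond the scatter.

Compound 4, `COc1cc2c(Oc3ccc(NC(=O)c4cc(-c5ccc(C)cc5)nc5ccc(F)cc45)cc3F)ccnc2cc1OCCCN1CCC(C)CC1`, has not yet been measured. It is made from compound 3 by the same kind of change: 4-methylphenyl in place of 3-methoxyphenyl on an aromatic carbon. The place descriptions for the two changes are the same word for word, so this is the same change made on the other core. Because compound 1 to compound 2 gave a 1.2-fold lower number from compound 1 to compound 2 (0.08 log units; within the scatter), the step from compound 3 to compound 4 is expected to be small as well, about a 1.2-fold lower number from compound 3 to compound 4 (0.08 log units; within the scatter). Compound 4 is therefore estimated at 700 nM, most likely between 350 nM and 1400 nM.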

Compound 4, half-maximal inhibitory concentration: 480 nM
Estimate against measurement, compound 4: 1.5-fold (0.16 log units) above; the measured number falls inside the stated range.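

In this assay, 4-methylphenyl in place of 3-methoxyphenyl gave a 1.8-fold lower number from compound 3 to compound 4 (0.24 log units; within the scatter) and so, on this second core as on the first, the swap leaves the number within the usual scatter. Set side by side, the two steps cannot be told apart: the same change on two cores in this assay, a 1.2-fold lower number (0.08 log units; within the scatter) from compound 1 to compound 2 and a 1.8-fold lower number (0.24 log units; within the scatter) from compound 3 to compound 4, 1.4-fold (0.16 log units) apart, within the scatter of two such steps. This shows that the swap carried over between these two cores without a step that stands clear of the scatter, but two small steps do not show that it would behave the same way on any other core, and they say nothing about how either group acts on the cells.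

The compounds shown place only these two phenyl groups at this position, which leaves open what a phenyl ring carrying an amine, a carboxylic acid or a longer chain would do there. On these data alone, all of this also rests on a single cell assay, so whether the swap stays as small on any other read-out remains open.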